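Hydroxy to methoxy on compound 1

The source may hold more compounds than are shown below. What is called first, only, known or untested is meant among the compounds shown, and "the series" means these compounds.

In a functional assay on UO-31 cells (Homo sapiens) for cytotoxicity, read by sulforhodamine B assay, with a stated time of 48 h (a lower number here means a stronger inhibitor of growth, a higher number a weaker inhibitor of growth), compound 1 `COc1cc(C(=O)c2ccc(OC)c(O)c2OC)cc(OC)c1O` gives 16600 nM and stands highest of the two measured numbers. Compound 2 `COc1cc(C(=O)c2ccc3c(c2)oc(=O)n3S(C)(=O)=O)cc(OC)c1OC` gives 6810 nM as the lower number, a gap beyond the scatter. Compound 3 `COc1ccc(C(=O)c2cc(OC)c(OC)c(OC)c2)c(OC)c1O` is still unmeasured. It differs from compound 1 by a single change methyl in place of hydrogen on an oxygen on an aromatic ring with methyl in place of hydrogen on an oxygen on an aromatic ring, which reads as hydroxy to methoxy. Among the measured compounds shown here, no measured pair shows this change, so the expected direction rests on little. For the measured compounds named here, a step to a lower number in this assay is expected, with compound 2 at 6810 nM as the only measured guide. The estimated step of a 5.5-fold lower number from compound 1 to compound 3 (0.74 log units; beyond the scatter) would lie beyond the scatter. For compound 3 the estimate is 3000 nM with an expected range from 400 nM to 15000 nM for repeated measurements.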

Compound 3, concentration for 50% growth inhibition: 48.9 nM
Compound 3: the middle estimate sits 61-fold (1.79 log units) above what was measured, and the stated range ends above it.
By their numbers in this assay, from the lowest: compound 3; then compound 2; then compound 1.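

In this assay, methyl in place of hydrogen on an oxygen on an aromatic ring gives a 340-fold lower number from compound 1 to compound 3 (2.53 log units; beyond the scatter), so this single position has a large effect on growth inhibition in the series. The step comes from one added carbon, and compound 3 still carries a free hydroxy group, so the change to methoxy at this one oxygen is enough for the drop and full capping of both hydroxy groups is not required. No measured data on the compounds shown speak to the reason for a step of this size.

From the compounds shown here alone, it remains open whether the effect is specific to methoxy or would also appear with a longer chain such as ethoxy on the same oxygen. The compounds shown also leave open how an amine in place of this hydroxy would read, and whether methoxy in place of the remaining hydroxy of compound 3 would move the number further.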